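The source may hold more compounds than are shown below. What is called first, only, known or untested is meant among the compounds shown, and "the series" means these compounds.

Measured in a functional assay on MCF7 cells (Homo sapiens) for cytotoxicity, read by MTT assay, with a stated time of 96 h; a higher number here means a weaker inhibitor, a lower number a stronger inhibitor:

compound 1 `Cc1cc2c(c(=O)o1)C(c1c[nH]c3ccc(Br)cc13)C(C#N)=C(N)O2`: 5000 nM
compound 2 `Cc1cc2c(c(=O)o1)C(c1ccc(Cl)s1)C(C#N)=C(N)O2`: 12000 nM
compound 3 `Cc1cc2c(c(=O)o1)C(c1c[nH]c3ccccc13)C(C#N)=C(N)O2`: 10000 nM

Compound 2 gives the highest of the three numbers in this assay. Compound 1 stands below it by a margin beyond the scatter, while compound 3 stands close enough that its value and that of compound 2 cannot be told apart. The three compounds share one core and differ only in the aromatic group attached to it.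

Compound 4 `Cc1cc2c(c(=O)o1)C(c1cccs1)C(C#N)=C(N)O2` is the untested partner of compound 2. The change that separates them is hydrogen in place of chloro on an aromatic carbon. One measured step resembles it: a 2.0-fold higher number from compound 1 to compound 3 (0.30 log units; within the scatter), where a halogen on an aromatic carbon was likewise exchanged for hydrogen, though on a different aromatic group. That step gave a higher number, but within the scatter. On this basis the step in this assay from compound 2 to compound 4 is expected to be small, tending if anything toward a higher number, and not clearly beyond the scatter. The estimate for compound 4 is 18000 nM, with a range from 8000 nM to 40000 nM, which means an expected step of a 1.5-fold higher number from compound 2 to compound 4 (0.18 log units; within the scatter).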

Compound 4, half-maximal inhibitory concentration: 15000 nM
Estimate against measurement, compound 4: 1.2-fold (0.08 log units) above, and the stated range covers the measured number.
By their numbers in this assay, from the lowest: compounds 1, 3, 2 and 4 (each within the scatter of the next, the first and the last beyond it).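

In this assay, going from the 5-chlorothiophen-2-yl group to the thiophen-2-yl group gives a 1.3-fold higher number from compound 2 to compound 4 (0.10 log units; within the scatter), so on this aromatic carbon next to the ring sulfur, hydrogen and chloro cannot be told apart in this assay. The earlier exchange of a halogen for hydrogen, a 2.0-fold higher number from compound 1 to compound 3 (0.30 log units; within the scatter), lay on a different aromatic group, and this pair now shows a step within the scatter on the five-membered ring with sulfur as well, so both such exchanges shown lie within the scatter. No measurement available here gives a reason for this result.

The compounds shown leave open whether an amine or a carboxylic acid on this same carbon of the thiophen-2-yl group would give a number beyond the scatter from that of compound 4. They also leave open whether a bromo group at this place would differ from chloro or hydrogen, and so whether this carbon tolerates other groups or only these two.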